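The source may report more compounds than this note shows. Statements on the series, on what has been measured and on what is new or still open speak of the compounds shown alone.

Compound 1 `CN(CCNCc1cn(-c2ccc(Cl)cc2)nn1)CCNc1ccnc2cc(Cl)ccc12` gives 14000 nM in a functional assay on NCI-H460 cells (Homo sapiens) for antiproliferative activity, read by sulforhodamine B assay, with a stated time of 72 h (a higher number here means a weaker inhibitor, a lower number a stronger inhibitor), and compound 2 `CN(CCNCc1cn(Cc2ccccc2)nn1)CCNc1ccnc2cc(Cl)ccc12` gives 32000 nM. For compound 3 `CN(CCNCc1cn(CC(=O)O)nn1)CCNc1ccnc2cc(Cl)ccc12` only a limit is reported, > 200000 nM. This is the limit of > 200000 nM in this assay, at which 1 of the 3 values shown sits. Compound 3 therefore stands at the weak end of the three measured compounds, reached by an at least 14-fold higher number from compound 1 to compound 3 (1.15 log units; beyond the scatter) and an at least 6.2-fold higher number from compound 2 to compound 3 (0.79 log units; beyond the scatter). Compound 4 `CN(CCNCc1cn(-c2ccnc3cc(Cl)ccc23)nn1)CCNc1ccnc2cc(Cl)ccc12` carries 7-chloroquinolin-4-yl in place of carboxymethyl on an aromatic nitrogen. This change runs opposite to the two steps above, which replaced an aromatic or benzyl substituent on that ring nitrogen with carboxymethyl and both lost potency. A large step back down is therefore expected, an at least 16-fold lower number from compound 3 to compound 4 (1.22 log units; beyond the scatter), bringing compound 4 close to compound 1. The estimate for compound 4 is 12000 nM, with a range of 3000 nM to 50000 nM.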

Compound 4, half-maximal inhibitory concentration: 16000 nM
The estimate for compound 4 lay 1.3-fold (0.12 log units) below the measured number; the range from low to high includes it.
By their numbers in this assay, from the lowest: compounds 1, 4 and 2 (each within the scatter of the next, the first and the last beyond it). At a limit, above all of these: compound 3.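

7-chloroquinolin-4-yl on this aromatic nitrogen matches 4-chlorophenyl, a 1.1-fold higher number from compound 1 to compound 4 (0.06 log units; within the scatter), and also benzyl, a 2.0-fold lower number from compound 2 to compound 4 (0.30 log units; within the scatter), so a second aromatic ring here brings no measurable gain over a single one. The return from carboxymethyl is large, an at least 12-fold lower number from compound 3 to compound 4 (1.09 log units; beyond the scatter). Compound 3 is only a limit, so the size of that step is a bound: the limit of > 200000 nM in this assay, at which 1 of the 4 values shown sits.

Open, from the compounds shown here alone, is whether an aromatic ring is needed here at all, which a plain butyl chain on this nitrogen would test. Also open, going by these compounds, is whether the loss in compound 3 follows from the carboxylic acid itself, which its methyl ester would separate.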